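Swapping Methyl for Methoxy on a Second Core

A few compounds are considered here, and "the series" means these few. Any claim that something is new, unique, unknown or untested is made for them only; others in the source may bear on it.

Compound 1 `Cc1cccc(Nc2nccc(-c3ccc(Br)cc3)n2)c1` and compound 2 `COc1cccc(Nc2nccc(-c3ccc(Br)cc3)n2)c1` share one core and differ in a single place: methoxy in place of methyl on an aromatic carbon. In a functional assay on HeLa cells (Homo sapiens) for antiproliferative activity, read by MTT assay (a higher number here means a weaker inhibitor, a lower number a stronger inhibitor), compound 1 gives 71000 nM, while compound 2 gives 153000 nM, so this change produced a 2.2-fold higher number from compound 1 to compound 2 (0.33 log units; beyond the scatter). Compound 3 `Cc1cccc(Nc2nccc(-c3ccc(Cl)cc3Cl)n2)c1` is built on a different core; how its core differs from that of compound 1 is not broken down here. In this assay compound 3 gives 7660 nM, the lowest of the three numbers. Compound 4 `COc1cccc(Nc2nccc(-c3ccc(Cl)cc3Cl)n2)c1` follows from compound 3 by the same change, at the same place: methoxy in place of methyl on an aromatic carbon. Among the measured compounds shown here, the step from compound 3 to compound 4 is expected to be about a 2.1-fold higher number from compound 3 to compound 4 (0.32 log units; beyond the scatter), resting on the one earlier example of this change, a 2.2-fold higher number from compound 1 to compound 2 (0.33 log units; beyond the scatter). Compound 4 is therefore expected to give roughly 16000 nM, most likely between 6000 nM and 45000 nM.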

Compound 4, half-maximal inhibitory concentration: 76400 nM
Beside the measured number, compound 4's estimate is 4.8-fold (0.68 log units) below it, and the stated range ends below it.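

In this assay the swap of methyl for methoxy weakens activity on this second core too, with a 10-fold higher number from compound 3 to compound 4 (1.00 log units; beyond the scatter) and a larger step than on the first core. The direction of the change carried over from one core to the other, but its size did not: the same change on two cores in this assay, a 2.2-fold higher number (0.33 log units; beyond the scatter) from compound 1 to compound 2 and a 10-fold higher number (1.00 log units; beyond the scatter) from compound 3 to compound 4, 4.6-fold (0.67 log units) apart, beyond the scatter of two such steps. Two cores cannot show what in a core sets the size of this step, nor how a third core would behave.

The compounds shown leave open how ethyl, ethoxy or hydroxyl at the same place would compare with methyl and methoxy. They also leave open whether an amine there would follow the same direction on both cores.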